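Adding one chloro group to compound 3

The compounds below may be only part of what the source reports. "The series", "measured", "known", "first", "only" and "open" are said of these compounds alone.

Compound 3 `CC(C)(C)NCc1c(C(=O)O)nn(-c2ccccc2)c1-c1ccc([N+](=O)[O-])cc1` offers no firm number to start from. In a functional assay on PC-3 cells (Homo sapiens) for inhibition, read by sulforhodamine B assay, with a stated time of 48 h (a lower number here means a stronger inhibitor of growth, a higher number a weaker inhibitor of growth), compound 3 gives > 634000 nM, which is a limit. Its close relative, compound 2 `COc1ccc(-c2c(CNC(C)(C)C)c(C(=O)O)nn2-c2ccccc2)cc1`, gives > 659000 nM, and this is also a limit. Among the compounds with values here, the one measured step between neighbours, a step that the two limits leave unreadable from compound 2 to compound 3, therefore has no readable size. Compound 1 `CCOC(=O)c1nn(-c2ccccc2)c(-c2ccc([N+](=O)[O-])cc2)c1CNC(C)(C)C` carries the same nitro group as compound 3 and was tested twice. In this assay compound 1 gives > 591000 nM; 128000 nM (2 entries), and one of these two entries is a true number.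

Compound 4 `CC(C)(C)NCc1c(C(=O)O)nn(-c2ccc(Cl)cc2)c1-c1ccc([N+](=O)[O-])cc1` differs from compound 3 in a single place: chloro in place of hydrogen on an aromatic carbon. Within the data shown here, no measured step tests this change, so the data give it no size. Among the measured compounds shown here, the only guide is that a number can be reached within this small family, as the second entry for compound 1 shows in the several entries of compound 1 in this assay, > 591000 nM; 128000 nM (2 entries). The estimate gives an at least 1.5-fold lower number from compound 3 to compound 4 (0.20 log units; that floor lies within the scatter), an expected shift toward stronger inhibition of growth, although another limit is also quite likely. For compound 4 the expected value is 400000 nM, with an estimated range of 120000 nM to 650000 nM.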

Compound 4, concentration for 50% growth inhibition: > 583000 nM
Compound 4 ended at the assay's limit; the forecaster's own chance of this, stated with the estimate: 60%; middle value at least 1.4-fold (0.16 log units) away from the limit.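

Compound 3 and compound 4 each end at a limit in this assay, so the step from compound 3 to compound 4 cannot be read and no size can be given for it. The compounds shown leave open whether chloro in place of hydrogen on this aromatic carbon shifts growth inhibition at all, and by how much.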